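This account rests on a few compounds, and the source may have more. Where it says the series, first, only, none or still open, it means among the compounds named here.

The measured compounds:
compound 1 `Cc1cc(N2CC[C@@H](C)[C@@H](N(C)c3ncnc4[nH]ccc34)C2)n2nc(SCc3ccc(F)cc3)nc2n1`, 26000 nM in a functional assay on HGC-27 cells (Homo sapiens) for inhibition, read by MTT assay, with a stated time of 72 h; on this read-out lower numbers stand for stronger inhibition and higher numbers for weaker inhibition
compound 2 `CCCCCc1c(C)nc2nc(SCc3ccc(Cl)cc3)nn2c1N1CC[C@@H](C)[C@@H](N(C)c2ncnc3[nH]ccc23)C1`, > 100000 nM in this assay

For the measured compounds named here, compound 1 is the only compound here with a number in this assay. Going by the values given here, for compound 2 the value of > 100000 nM is a limit of the assay, not a number, as the line the limit of > 100000 nM in this assay, at which 1 of the 2 values shown sits, records; it shows only that compound 2 is weaker than that limit. Among the compounds with values here, no step between two measured compounds can be drawn from these two, so there is no measured yardstick for the change that leads to compound 3.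

Compound 3 `Cc1cc(N2CC[C@@H](C)[C@@H](N(C)c3ncnc4[nH]ccc34)C2)n2nc(SCCCc3ccccc3)nc2n1` differs from compound 1 in one place, (phenethyl in place of 4-fluorophenyl on a saturated chain carbon bound to a sulfur). The 4-fluorobenzyl on the sulfur becomes a 3-phenylpropyl, so the aromatic ring keeps its place in the molecule but sits one bond further from the sulfur and loses its fluorine. With no measured step of this kind shown, the expected step of a 1.5-fold higher number from compound 1 to compound 3 (0.19 log units; within the scatter) in this assay is small, and it could fall on either side of the scatter. For compound 3 the expected value in this assay is 40000 nM, with a range from 10000 nM to 100000 nM.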

Compound 3, half-maximal inhibitory concentration: > 100000 nM
Compound 3: no number, only a limit (the forecaster's own chance of this, stated with the estimate: 30%); middle value at least 2.5-fold (0.39 log units) away from the limit.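

In this assay, compound 3 gives > 100000 nM, which is a limit of the assay and not a number. For the compounds shown here, this is the first step that can be read at this place, on a saturated chain carbon bound to a sulfur: replacing 4-fluorobenzyl with 3-phenylpropyl gives an at least 3.8-fold higher number from compound 1 to compound 3 (0.58 log units; beyond the scatter), so this change to the group on the sulfur weakens inhibition by more than the usual scatter of repeated measurements. Compound 1 is now the only compound shown with an actual number, so it remains the single measured reference point for this series: the limit of > 100000 nM in this assay, at which 2 of the 3 values shown sit.

The change lengthens the chain and removes the fluorine at the same time, so these compounds cannot show which of the two alterations accounts for the step; a plain benzyl on the sulfur, carrying no fluorine on its ring, would separate them. Also open, as far as these compounds go, is how the activity would respond to a shorter chain on the sulfur, or to an amine or a carboxylic acid at the end of the chain in place of the aromatic ring.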